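Amide nitrogen substituent: hydroxyethyl replaced by cyclopropyl

The source may hold more compounds than are shown below. What is called first, only, known or untested is meant among the compounds shown, and "the series" means these compounds.

Among the measured compounds shown here, compound 1 `O=C(/C=C1\CCc2ccc(F)cc21)NCCO` has the higher number of the two compounds measured so far. In a functional assay on the whole organism with Rattus norvegicus as the target, at a dose of 20 mg/kg by the oral route (on this read-out higher numbers stand for more inhibition at the one dose given (going by the name of the read-out) and lower numbers for less inhibition), compound 1 gives 42%. Compound 2 `COc1ccc2c(c1)CC/C2=C\C(N)=O`, which shares the core but carries a different ring substituent and an unsubstituted amide, gives in this assay only 18%; the gap between compound 1 and compound 2 lies beyond the usual scatter of this read-out. For the measured compounds named here, no pair of measured compounds differs in a single place, so no measured step is available as a guide.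

Compound 3 `O=C(/C=C1\CCc2ccc(F)cc21)NC1CC1` has not been measured. It differs from compound 1 by cyclopropyl in place of 2-hydroxyethyl on an amide-type nitrogen. Nothing in the measured data speaks to what exchanging a 2-hydroxyethyl for a cyclopropyl on an amide-type nitrogen does in this series, so the direction of the step cannot be read from the numbers. The step of a number 4 percentage points lower from compound 1 to compound 3 (within the scatter) is therefore expected to be small, most likely within the scatter, with a wide margin in either direction. For compound 3 the expected value in this assay is 38%, with a range from 15% to 60%.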

Compound 3, a percentage reported as inhibition, in the whole organism at one dose (the size of the read-out at that dose, not a potency): 5%
Estimate against measurement, compound 3: 33 percentage points above; the whole stated range lies above it.
By their numbers in this assay, from the lowest: compound 3; then compound 2; then compound 1.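

Among the compounds shown here, on the amide-type nitrogen of the core of compound 1, the choice of substituent has a large effect in this assay: cyclopropyl in place of 2-hydroxyethyl gives a number 37 percentage points lower from compound 1 to compound 3 (beyond the scatter), and this is the first step that differs in one place only. Each group has 3 heavy atoms, so that count does not separate them; they differ in the oxygen, the hydrogen-bond donor and the hydrogen-bond acceptor of the 2-hydroxyethyl and in the three-membered ring of the cyclopropyl, and this one step cannot assign its size to any one of these features. Nothing at hand explains the step.

Going by these compounds, it remains open whether the oxygen or the ring matters more: an ethyl or a 2-methoxyethyl on the same nitrogen would help to separate the two, and a 3-hydroxypropyl or a 2-aminoethyl would extend the comparison to a longer chain and to an amine. On these data alone, it also remains open whether the same exchange has a similar effect with a methoxy group in place of the fluoro group on the core.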